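The source may report more compounds than this note shows. Statements on the series, on what has been measured and on what is new or still open speak of the compounds shown alone.

Of the compounds shown here, two built on one shared core have been measured so far in an ADME assay on microsomes from liver (Mus musculus) for metabolic stability; a higher number here means that the compound lasts longer, a lower number that the compound disappears faster. Compound 1 (`Cc1c(-c2ccc(-c3ccccc3F)cc2)nc2ccc(F)cc2c1C(N)=O`) gives 1.08 h, and compound 2 (`Cc1c(-c2ccc(-c3ccccc3F)cc2)nc2ccc(F)cc2c1C(=O)NO`) gives 0.6 h. Among the compounds with values here, compound 2 therefore sits within the scatter of the only other number available, and the two cannot be ranked. Within the data shown here, the single measured step, a 1.8-fold lower number from compound 1 to compound 2 (0.26 log units; within the scatter), comes with hydroxy in place of hydrogen on an amide-type nitrogen.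

Compound 3 (`CCONC(=O)c1c(C)c(-c2ccc(-c3ccccc3F)cc2)nc2ccc(F)cc12`) changes compound 2 at that same group: ethyl in place of hydrogen on an oxygen. In plainer terms, hydroxy becomes ethoxy, with ethyl in place of hydrogen on an oxygen. Among the measured compounds shown here, no measured step adds an ethyl group, so the evidence here is thin. For the measured compounds named here, the only guide is a 1.8-fold lower number from compound 1 to compound 2 (0.26 log units; within the scatter), a different change that stayed inside the scatter, so no shift beyond the scatter is expected in this assay, in either direction. The expected change is a 1.2-fold lower number from compound 2 to compound 3 (0.08 log units; within the scatter). The estimated half-life of compound 3 is 0.5 h, with an expected range from 0.2 h to 1.2 h.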

Compound 3, half-life: 0.3 h
For compound 3 the middle estimate is 1.7-fold (0.22 log units) above the measured one, and the stated range covers the measured number.
By their numbers in this assay, from the lowest: compounds 3, 2 and 1 (each within the scatter of the next, the first and the last beyond it).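

In this assay, turning the hydroxy of compound 2 into the ethoxy of compound 3 gives a 2.0-fold lower number from compound 2 to compound 3 (0.30 log units; within the scatter) and so, taken alone, this change on the oxygen cannot be told apart from the variation between repeated measurements. Within the data shown here, measured from the plain amide instead, the ethoxyamino group gives a 3.6-fold lower number from compound 1 to compound 3 (0.56 log units; beyond the scatter) and this is the first step to clear the scatter, although only modestly. The amide of compound 1 and the ethoxycarbamoyl group of compound 3 can therefore be told apart at this position, even though neither of the smaller steps through compound 2 can be read as a real change on its own, and no measurement shown here accounts for the gap.

Going by these compounds, it remains open whether the trend follows chain length on this oxygen, which a smaller methoxy or a longer propoxy group would help to test. Also unanswered is how a carboxylic acid or an amine would fare in place of the carbamoyl group on the same core.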